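This account rests on a few compounds, and the source may have more. Where it says the series, first, only, none or still open, it means among the compounds named here.

In a functional assay on ileum (Cavia porcellus) for antagonist activity (on this read-out higher numbers stand for weaker inhibition and lower numbers for stronger inhibition), compound 2 (`CC(=O)c1ccc(OCC(O)COc2ccc3c(O)c([N+](=O)[O-])c(=O)oc3c2)cc1O`) is reported only as > 20000 nM, which is a limit and not a number. Compound 1 (`CCCc1cc(C(C)=O)ccc1OCC(O)COc1ccc2c(O)c([N+](=O)[O-])c(=O)oc2c1`), which carries a propyl group, gives 700 nM in this assay. Compound 3 (`CCCc1c(OCC(O)COc2ccc3c(O)c([N+](=O)[O-])c(=O)oc3c2)ccc(C(C)=O)c1O`) differs from compound 2 by propyl in place of hydrogen on an aromatic carbon, ortho to a hydroxy group. Resting on compound 1 at 700 nM, a large fall in this assay, toward stronger inhibition and beyond the scatter, is expected. The estimated step is an at least 66-fold lower number from compound 2 to compound 3 (1.82 log units; beyond the scatter). For compound 3 the expected value is 300 nM, with an estimated range of 50 nM to 2000 nM.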

Compound 3, half-maximal inhibitory concentration: 80 nM
Compound 3: the middle estimate sits 3.8-fold (0.57 log units) above what was measured; measured number inside the range.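

Compound 2 is held only by a limit, not a number: the limit of > 20000 nM in this assay, at which 1 of the 3 values shown sits. Even so, in this assay propyl on this aromatic carbon, ortho to a hydroxy group, gives an at least 250-fold lower number from compound 2 to compound 3 (2.39 log units; beyond the scatter) and so is the larger of the two steps into compound 3. The hydroxy group still adds to the propyl group here, with an 8.8-fold lower number from compound 1 to compound 3 (0.94 log units; beyond the scatter).

On these data alone, whether a longer chain such as butyl would go further on this carbon stays open. So does whether a methoxy group could stand in for the hydroxy group.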